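Notes on the step from compound 2 to compound 3

This account rests on a few compounds, and the source may have more. Where it says the series, first, only, none or still open, it means among the compounds named here.

Measured in a functional assay on L1210 cells (Mus musculus) for antiproliferative activity, read by MTT assay; on this read-out lower numbers stand for stronger inhibition and higher numbers for weaker inhibition:
- compound 1 `COc1ccc(/C=N/NC(=O)c2cn(C3CC3)c3cc(N/N=C/c4ccc(OC)cc4)c(F)cc3c2=O)cc1`: <= 25000 nM (a limit)
- compound 2 `O=C(N/N=C/c1ccc(F)cc1)c1cn(C2CC2)c2cc(N/N=C/c3ccc(F)cc3)c(F)cc2c1=O`: <= 25000 nM (a limit)

Both values sit at one limit, (the limit of <= 25000 nM in this assay, at which 2 of the 2 values shown sit). Compound 2 therefore stands at a limit and not at a number, <= 25000 nM.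

Compound 3 `O=C(N/N=C/c1ccc(F)cc1)c1cn(C2CC2)c2cc(N3CCNCC3)c(F)cc2c1=O` is not yet measured. It differs from compound 2 as follows: a group of 6 heavy atoms (4 carbon, 2 nitrogen; one six-membered non-aromatic ring with 2 hetero atoms) in place of a group of 10 heavy atoms (7 carbon, 2 nitrogen, 1 fluorine; one six-membered aromatic ring of carbon only), on an aromatic carbon.

Going by the values given here, no measured step gives a size for this change, so no shift beyond the scatter is expected in this assay, and no direction can be favoured. The expected change is a step that the limit leaves unreadable from compound 2 to compound 3.

Compound 3 is estimated at 15000 nM, with an expected range from 4000 nM to 50000 nM.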

Compound 3, half-maximal inhibitory concentration: <= 25000 nM
Compound 3 gave a limit, no number (the forecaster's own chance of this, stated with the estimate: 45%); the middle value is on the limit's open side.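

No step can be read from compound 2 to compound 3: both stand at a limit, not at a number. Left open in this assay are the size and direction of any change that comes with the piperazin-1-yl group.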